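The source may report more compounds than this note shows. Statements on the series, on what has been measured and on what is new or still open speak of the compounds shown alone.

In a physicochemical assay for solubility, in phosphate buffer, measured as kinetic solubility (a higher number here means a more soluble compound, a lower number a less soluble compound), compound 1 `CC(C)[C@@H](c1ccc(-c2ccc3cccc(F)c3c2)[nH]c1=O)[C@@H]1OC(=O)NC1=O` gives 27400 nM. Compound 2 `O=C1NC(=O)/C(=C/C(c2ccccc2)c2ccc(-c3ccc4cccc(F)c4c3)[nH]c2=O)O1` gives 32800 nM, which lies within the scatter of the number for compound 1, so the two stand level at the top of the measured set. Compound 3 `O=C1NC(=O)/C(=C/C(Cc2ccccc2)c2ccc(-c3ccc4cccc(F)c4c3)[nH]c2=O)O1` gives 9100 nM, the lowest of the three numbers and clearly apart from both others.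

Compound 4 `CC(C)[C@H](C[C@@H]1OC(=O)NC1=O)c1ccc(-c2ccc3cccc(F)c3c2)[nH]c1=O` has not yet been measured. Its structure departs from that of compound 1 in one place: (2,4-dioxo-1,3-oxazolidin-5-yl)methyl in place of 2,4-dioxo-1,3-oxazolidin-5-yl on a saturated chain carbon bound to an aromatic carbon and a saturated chain carbon. Going by the values given here, no measured pair shows this exact change. The closest guide is a 3.6-fold lower number from compound 2 to compound 3 (0.56 log units; beyond the scatter), a modest step beyond the scatter, in which benzyl takes the place of phenyl. That swap also puts a longer group in place of a shorter one, but it involves a different group at a different place, so it offers only indirect support. It points to a lower number for compound 4, probably by a similar or somewhat smaller margin, although no change beyond the scatter remains possible. The expected change is a 2.0-fold lower number from compound 1 to compound 4 (0.29 log units; within the scatter). For compound 4 the estimated value is 14000 nM, with an expected range from 5500 nM to 35000 nM.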

Compound 4, solubility: 21100 nM
Estimate against measurement, compound 4: 1.5-fold (0.18 log units) below, within the range that was stated.
By their numbers in this assay, from the lowest: compound 3; then compounds 4, 1 and 2 (each within the scatter of the next).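

In this assay, (2,4-dioxo-1,3-oxazolidin-5-yl)methyl in place of 2,4-dioxo-1,3-oxazolidin-5-yl on a saturated chain carbon bound to an aromatic carbon and a saturated chain carbon gives a 1.3-fold lower number from compound 1 to compound 4 (0.11 log units; within the scatter), so the two compounds stand level. Going by these compounds alone, the only earlier step of a longer group for a shorter one, a 3.6-fold lower number from compound 2 to compound 3 (0.56 log units; beyond the scatter), lies beyond the scatter, and the new step shows that such a swap does not always go with a change of that kind, although compound 3 remains the case against any general rule and its step involves a different group at a different place. No measurement shown here bears on why the number holds at this place.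

The compounds shown leave open whether a longer chain carrying the 2,4-dioxo-1,3-oxazolidin-5-yl ring, or a carboxylic acid or an amine in place of that ring, would stay within the scatter of compound 1 in this assay. They also leave open whether the same swap would read the same way with a phenyl or benzyl group on that saturated chain carbon.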